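Triazolyl in place of carboxymethoxy: clearance notes

This account rests on a few compounds, and the source may have more. Where it says the series, first, only, none or still open, it means among the compounds named here.

Measured in an in vitro ADME assay on microsomes from liver (Homo sapiens) for metabolic stability; on this read-out higher numbers stand for fast clearance and lower numbers for slow clearance:
- Compound 1 `Cc1nnc(C2CCN(c3ccccn3)CC2)n1Cc1ccccc1`: < 8 mL.min-1.g-1, a limit
- Compound 2 `CCCCc1nnc(C2CCN(c3ccccn3)CC2)n1Cc1ccccc1`: 154 mL.min-1.g-1
- Compound 3 `O=C(O)COCc1nnc(C2CCN(c3ccccn3)CC2)n1Cc1ccccc1`: < 8 mL.min-1.g-1, a limit

Compound 3 stands at the limit of < 8 mL.min-1.g-1 in this assay, at which 2 of the 3 values shown sit, so its position is known only as a limit. Compound 4 `c1ccc(Cn2c(Cn3nccn3)nnc2C2CCN(c3ccccn3)CC2)cc1` differs from it by this change: 2H-1,2,3-triazol-2-yl in place of carboxymethoxy on a saturated chain carbon bound to an aromatic carbon. Three measured steps at this same place bear on the change. The first is large: an at least 19-fold higher number from compound 1 to compound 2 (1.28 log units; beyond the scatter). The second is also large: an at least 19-fold lower number from compound 2 to compound 3 (1.28 log units; beyond the scatter). The third cannot be sized: a step that the two limits leave unreadable from compound 1 to compound 3. Substitution at this place can therefore shift this assay strongly, but only compound 2 has a value clear of the limit. Within the data shown here, no measured compound carries the 2H-1,2,3-triazol-2-yl group. A small upward move is expected, well short of an at least 19-fold higher number from compound 1 to compound 2 (1.28 log units; beyond the scatter), and a result that again reads only as a limit would not surprise. The expected change is an at least 1.5-fold higher number from compound 3 to compound 4 (0.17 log units; that floor lies within the scatter). For compound 4 the estimated value is 12 mL.min-1.g-1, with an expected range of 4 mL.min-1.g-1 to 45 mL.min-1.g-1.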

Compound 4, intrinsic clearance in microsomes: 19 mL.min-1.g-1
Beside the measured number, compound 4's estimate is 1.6-fold (0.20 log units) below it, within the range that was stated.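

In this assay, compound 4 is the second compound at this place, after compound 2, with a value clear of the limit, and the 2H-1,2,3-triazol-2-yl group reads as an at least 2.3-fold higher number from compound 3 to compound 4 (0.37 log units; beyond the scatter) and as an at least 2.3-fold higher number from compound 1 to compound 4 (0.37 log units; beyond the scatter). Against propyl, the only other substituent here with a readable value, the same group reads as an 8.1-fold lower number from compound 2 to compound 4 (0.91 log units; beyond the scatter), which places compound 4 at an intermediate level that the earlier values did not show. Both steps from the limits give only floors, not sizes: the limit of < 8 mL.min-1.g-1 in this assay, at which 2 of the 4 values shown sit.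

The compounds shown do not tell whether the level of compound 4 is specific to the 2H-1,2,3-triazol-2-yl group or would also hold for a pyrazole ring, a methoxy group or an amine at this place. From the compounds shown here alone, how far compound 1 and compound 3 lie under their limits also stays open.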